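This account rests on a few compounds, and the source may have more. Where it says the series, first, only, none or still open, it means among the compounds named here.

Of the compounds shown here, three of one series have been measured in a physicochemical assay for solubility, using the shake flask method, in simulated intestinal fluid, measured as kinetic solubility, with a stated time of 2 h, at 25 degrees C, at pH 6.5; a higher number here means a more soluble compound, a lower number a less soluble compound. Compound 1 `CCOC(=O)c1nc(C)c2c(c1N)C(=O)N(Cc1ccccc1)C2=O` returns only a limit of the assay, < 5000 nM. Compound 2 `Cc1nc(C(=O)OC2CC2)c(N)c2c1C(=O)N(Cc1ccccc1)C2=O` gives 202000 nM in this assay, and compound 3 `Cc1noc(-c2nc(C)c3c(c2N)C(=O)N(CC2CCNCC2)C3=O)n1` gives 160000 nM. Among the measured compounds shown here, the one measured step, an at least 40-fold higher number from compound 1 to compound 2 (1.60 log units; beyond the scatter), concerns the ester group and not the substituent on the amide-type nitrogen. Among the two numbers shown, compound 3 stands lowest, with compound 2 nearest to it and within the scatter, so no order between these two can be read. Compound 4 `Cc1noc(-c2nc(C)c3c(c2N)C(=O)N(Cc2ccncc2)C3=O)n1` differs from compound 3 in one place: pyridin-4-yl in place of piperidin-4-yl on a saturated chain carbon bound to an amide-type nitrogen in a ring. For the measured compounds named here, no measured step bears on this change; the single step available alters a different part of the molecule and gives no guide to its size or direction. Without a matching comparison, compound 4 is expected to give a lower number than compound 3, an estimated step of a 5.3-fold lower number from compound 3 to compound 4 (0.73 log units; beyond the scatter). The estimated solubility of compound 4 is 30000 nM, with a range from 5000 nM to 150000 nM.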

Compound 4, solubility: 26400 nM
Compound 4: middle estimate off by 1.1-fold (0.06 log units), on the high side; the measured number falls inside the stated range.
By their numbers in this assay, from the lowest: compound 4; then compounds 3 and 2 (each within the scatter of the next). At a limit, below all of these: compound 1.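

In this assay, among the compounds shown here, the change at the saturated chain carbon bound to an amide-type nitrogen in a ring gives a 6.1-fold lower number from compound 3 to compound 4 (0.78 log units; beyond the scatter), the first measured step at this place, since the earlier step concerned only the ester group. Piperidin-4-yl and pyridin-4-yl have the same count of heavy atoms, yet the non-aromatic ring with a hydrogen-bond donor and the aromatic ring without one are separated by a step beyond the scatter. Compound 4 does not sit at a limit of the assay, so both ends of this step are numbers, and the one limit shown belongs to compound 1: the limit of < 5000 nM in this assay, at which 1 of the 4 values shown sits.

A single pair cannot show whether the step holds on the ester-bearing cores of compound 1 and compound 2. How a morpholine ring or an open-chain amine at this place would compare also remains open, and no cause for the step can be read from these compounds.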